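Hepatocyte clearance notes: oxan-4-yl to methyl

This account rests on a few compounds, and the source may have more. Where it says the series, first, only, none or still open, it means among the compounds named here.

Measured so far:
compound 1, `CC(C)n1nc(-c2ccnc3[nH]c(C4CCN(CC(=O)N(C)C)CC4)cc23)ccc1=O`: 3.1 uL/min
compound 2, `CN(C)C(=O)CN1CCC(c2cc3c(-c4ccc(=O)n(CC5CCOCC5)c4)ccnc3[nH]2)CC1`: 1.8 uL/min

In an ADME assay on cells (Hepatocyte, Rattus norvegicus) for metabolic stability (on this read-out higher numbers stand for fast clearance and lower numbers for slow clearance), compound 1 gives 3.1 uL/min and compound 2 gives 1.8 uL/min. Compound 2 and compound 1 sit within the usual scatter of one another, so neither stands apart; both show slow clearance in this assay.

The next compound, compound 3, `CCn1cc(-c2ccnc3[nH]c(C4CCN(CC(=O)N(C)C)CC4)cc23)ccc1=O`, is still to be measured in this assay. It differs from compound 2 in one place: methyl in place of oxan-4-yl on a saturated chain carbon bound to an aromatic nitrogen.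

With no measured step of this kind in the series, the expectation rests only on the two numbers known. Both lie at the slow end of this assay, and the expected step of a 1.4-fold higher number from compound 2 to compound 3 (0.14 log units; within the scatter) is none beyond the scatter. Compound 3 is thus estimated at 2.5 uL/min in this assay, with a range from 1 uL/min to 6 uL/min.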

Compound 3, intrinsic clearance in a liver preparation (reported as CLH), per the amount of preparation that the assay uses in the Hepatocyte assay: < 1 uL/min
Compound 3: no number, only a limit; the forecaster's own chance of this, stated with the estimate: 10%; middle value at least 2.5-fold (0.39 log units) away from the limit.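

Compound 3 gives no number in this series, only a limit: the limit of < 1 uL/min in the Hepatocyte assay, at which 1 of the 3 values shown sits.

For the compounds shown here, in the Hepatocyte assay, only a floor can be read for the change of oxan-4-yl to methyl, an at least 1.8-fold lower number from compound 2 to compound 3 (0.25 log units; that floor lies within the scatter), so this position shows no step that can be called real, although a larger one remains possible. Going by these compounds alone, the change on the aromatic carbon, read in the Hepatocyte assay as an at least 3.1-fold lower number from compound 1 to compound 3 (0.49 log units; beyond the scatter), is the first step to clear the scatter. In a physicochemical assay for lipophilicity, using the shake flask method, measured as octanol-water partition, at pH 7.4 (a higher number here means a more lipophilic compound, a lower number a more polar compound), compound 2 gives 1.4 and compound 3 gives 1.2, values within the scatter of each other.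

From the compounds shown here alone, the true size of both clearance steps stays open while compound 3 rests on a limit. Also open, going by these compounds, is how an amine or a carboxylic acid in place of methyl, on that saturated chain carbon, would read.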